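Swapping the pendant aryl on a shared sulfonyl quinoline core

The compounds below may be only part of what the source reports. "The series", "measured", "known", "first", "only" and "open" are said of these compounds alone.

Measured so far:
Compound 1, `COc1ccc(S(=O)(=O)c2cnc3cc(F)ccc3c2-c2cccc(Cl)c2)cc1Cl`, gives 1.19 mL/min.
Compound 2, `O=S(=O)(c1cc(Cl)cc(Cl)c1)c1cnc2cc(F)ccc2c1-c1ccc(F)cc1`, gives 0.18 mL/min.

The read-out throughout is an ADME assay on microsomes from liver (Homo sapiens) for metabolic stability, tested at 2.5 uM; on this read-out higher numbers stand for fast clearance and lower numbers for slow clearance. Of the two numbers in hand, compound 2 stands lowest, and its nearest neighbour is compound 1, whose value lies well beyond the usual scatter above it. For the measured compounds named here, compound 1 and compound 2 differ in more than one place, so no single step between them can be drawn; their two values show only that the pair spans a wide range in this assay.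

Compound 3, `O=S(=O)(c1cc(Cl)cc(Cl)c1)c1cnc2cc(F)ccc2c1-c1cccc(Cl)c1`, shares the sulfonyl aryl of compound 2 and the pendant aryl of compound 1. Its change from compound 2 is 3-chlorophenyl in place of 4-fluorophenyl on an aromatic carbon. Going by the values given here, with no measured step of this single kind available, the expectation rests on the two values alone: compound 1 carries the same 3-chlorophenyl and gives the higher number, so the step from compound 2 to compound 3 is estimated as a modest rise, a 1.9-fold higher number from compound 2 to compound 3 (0.29 log units; within the scatter), of a size that may or may not clear the scatter. Compound 3 is therefore expected to give 0.35 mL/min, within the range 0.15 mL/min to 0.85 mL/min.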

Compound 3, intrinsic clearance in a liver preparation (reported as CLH), per the amount of preparation that the assay uses: 0.93 mL/min
Estimate against measurement, compound 3: 2.7-fold (0.42 log units) below; the whole stated range lies below it.
By their numbers in this assay, from the lowest: compound 2; then compounds 3 and 1 (each within the scatter of the next).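

In this assay, 3-chlorophenyl in place of 4-fluorophenyl on the aromatic carbon opposite the ring nitrogen gives a 5.2-fold higher number from compound 2 to compound 3 (0.71 log units; beyond the scatter), which shows that the number is sensitive to the pendant aryl at this position when the 3,5-dichlorophenyl sulfonyl group is held fixed. By contrast, with 3-chlorophenyl held fixed, 3,5-dichlorophenyl in place of 3-chloro-4-methoxyphenyl on the sulfonyl sulfur gives a 1.3-fold lower number from compound 1 to compound 3 (0.11 log units; within the scatter), so this change does not separate the two compounds. Among these single-place changes, only the one at the pendant aryl clears the scatter, and no accompanying measurement explains that step.

The step from 4-fluorophenyl to 3-chlorophenyl changes both the halogen and where it sits on the ring, so the compounds shown cannot assign the step to either alone; 4-chlorophenyl and 3-fluorophenyl would separate the two. As far as these compounds go, it also remains open whether 4-fluorophenyl would give a similarly low number alongside the 3-chloro-4-methoxyphenyl sulfonyl group, and how a nitrile or a methoxy group on the pendant ring would read.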